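Adding a Methoxy Group Twice on Two Related Cores

The source may hold more compounds than are shown below. What is called first, only, known or untested is meant among the compounds shown, and "the series" means these compounds.

Going by the values given here, compound 2 `COc1cc(OC)cc([C@@H]2C(=O)c3cc(OC)cc(OC)c3[C@H]2c2ccccc2)c1` is the only compound here with a measured number. In a functional assay on RAW264.7 cells (Mus musculus) for inhibition, with stated times of 2 h and 24 h (on this read-out lower numbers stand for stronger inhibition and higher numbers for weaker inhibition), compound 2 gives 27100 nM. Compound 1 `COc1ccc([C@@H]2c3c(OC)cc(OC)cc3C(=O)[C@H]2c2cc(OC)cc(OC)c2)cc1` differs from it by methoxy in place of hydrogen on an aromatic carbon. In this assay compound 1 gives only a limit, > 200000 nM. The step of an at least 7.3-fold higher number from compound 2 to compound 1 (0.86 log units; beyond the scatter) is thus known only as a bound, because of the limit of > 200000 nM in this assay, at which 2 of the 3 values shown sit.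

Compound 3 `COc1cc(OC)cc([C@@H]2C(SCc3ccccc3)c3cc(OC)cc(OC)c3[C@H]2c2ccccc2)c1` rests on a different core; the difference between the two cores is not broken down here. In this assay compound 3 gives only a limit, > 200000 nM.

Compound 4 `COc1ccc(CSC2c3cc(OC)cc(OC)c3[C@@H](c3ccccc3)[C@@H]2c2cc(OC)cc(OC)c2)cc1` has not yet been measured. It arises from compound 3 by methoxy in place of hydrogen on an aromatic carbon, the same change that separates compound 2 from compound 1. That earlier change weakened inhibition by the bound an at least 7.3-fold higher number from compound 2 to compound 1 (0.86 log units; beyond the scatter), and the starting point is already at the assay's ceiling, so compound 4 is expected to stay at or beyond that ceiling, with an expected step that the limit leaves unreadable from compound 3 to compound 4. The estimate for compound 4 is 300000 nM, most likely between 150000 nM and 1000000 nM.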

Compound 4, half-maximal inhibitory concentration: > 200000 nM
Compound 4 gave a limit, no number; the forecaster's own chance of this, stated with the estimate: 85%; the middle value lies beyond the limit too.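

In this assay compound 4 gives only a limit, > 200000 nM. No step from compound 3 to compound 4 can be read, because neither compound has an exact number: the limit of > 200000 nM in this assay, at which 3 of the 4 values shown sit.

The compounds shown leave open whether changing benzyl to 4-methoxybenzyl alters inhibition at all on the core of compound 3.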